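The source may hold more compounds than are shown below. What is called first, only, known or untested is meant among the compounds shown, and "the series" means these compounds.

Measured so far in a functional assay on A549 cells (Homo sapiens) for cytotoxicity, read by MTT assay, with a stated time of 48 h; a lower number here means a stronger inhibitor, a higher number a weaker inhibitor:

compound 1, `Cc1ccc(S(=O)(=O)/N=C(/CCNC2=CC(=O)c3ccccc3C2=O)Nc2ccc(Cl)cc2)cc1`: 29900 nM
compound 2, `Cc1ccc(S(=O)(=O)/N=C(/CCNC2=CC(=O)c3ccccc3C2=O)Nc2ccc(F)cc2)cc1`: 9330 nM
compound 3, `Cc1ccc(S(=O)(=O)/N=C(/CCNC2=CC(=O)c3ccccc3C2=O)Nc2ccc(F)c(F)c2)cc1`: 16700 nM

Compound 3 gives the second highest of the three numbers. Its nearest neighbour is compound 2, with a 1.8-fold higher number from compound 2 to compound 3 (0.25 log units; within the scatter); its furthest is compound 1, with a 1.8-fold lower number from compound 1 to compound 3 (0.25 log units; within the scatter). Both of these steps lie within the scatter, so compound 3 cannot be placed above or below either of them. Among the measured compounds shown here, the only step beyond the scatter is a 3.2-fold lower number from compound 1 to compound 2 (0.51 log units; beyond the scatter), and it is modest.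

Compound 4, `COc1cc(N/C(CCNC2=CC(=O)c3ccccc3C2=O)=N\S(=O)(=O)c2ccc(C)cc2)cc(OC)c1OC`, is not yet measured. The change is 3,4,5-trimethoxyphenyl in place of 3,4-difluorophenyl on an amine nitrogen. For the measured compounds named here, none of the measured steps touches a trimethoxy pattern; all three concern halogen swaps on the same ring, and the whole series spans only a narrow band in this assay. What they show is that changes on this aryl ring move the number little. Going by the values given here, the entering group is larger and carries acceptors, so a step of some size in either direction cannot be ruled out, but no measured step supports expecting a large one.

Compound 4 is therefore expected near 15000 nM, in the range 4000 nM to 60000 nM. For compound 4 the expected step is a 1.1-fold lower number from compound 3 to compound 4 (0.05 log units; within the scatter), that is, none beyond the scatter.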

Compound 4, half-maximal inhibitory concentration: 7940 nM
Estimate against measurement, compound 4: 1.9-fold (0.28 log units) above; the measured number falls inside the stated range.
By their numbers in this assay, from the lowest: compounds 4, 2, 3 and 1 (each within the scatter of the next, the first and the last beyond it).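

Among the compounds shown here, the 3,4,5-trimethoxyphenyl group is the first group without halogen on the amine nitrogen whose other neighbour is the carbon with a double bond to nitrogen, and in this assay it does not raise the number, despite 12 heavy atoms against 8 for 3,4-difluorophenyl and 3 hydrogen-bond acceptors against 0 (a 2.1-fold lower number from compound 3 to compound 4 (0.32 log units; beyond the scatter)). The 4-chlorophenyl group now stands apart from two groups rather than one (a 3.8-fold lower number from compound 1 to compound 4 (0.58 log units; beyond the scatter)), while 3,4,5-trimethoxyphenyl and 4-fluorophenyl cannot be separated (a 1.2-fold lower number from compound 2 to compound 4 (0.07 log units; within the scatter)), so halogen is not needed at this position for a number at this level, and neither larger size nor added acceptors carries the number upward in these compounds. Nothing available explains why this change has the effect seen.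

As far as these compounds go, it remains open whether all three methoxy groups contribute, or whether a single methoxy group, a hydroxyl group or an amine on the aryl ring would give a similar number. From the compounds shown here alone, a carboxylic acid on that ring and a longer chain on the shared core are also open, as is whether the step would carry over to either change.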